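Acetyl for Fluoro: the Step from Compound 2 to Compound 3

The source may report more compounds than this note shows. Statements on the series, on what has been measured and on what is new or still open speak of the compounds shown alone.

Compound 1 `Oc1ccccc1CNc1ccccc1` is reported as "not active" (no number reported) in a functional assay on Jurkat cells (Homo sapiens) for activation, with a stated time of 24 h (on this read-out lower numbers stand for an effect already at smaller amounts and higher numbers for an effect only at larger amounts of compound), with no number given. Compound 2 `Oc1ccccc1CNc1ccc(-c2ccc(F)cc2)cc1` gives 3860 nM in this assay and is the only numerical result shown. Compound 3 `CC(=O)c1ccc(-c2ccc(NCc3ccccc3O)cc2)cc1` has not yet been measured; it differs from compound 2 in one place: acetyl in place of fluoro on an aromatic carbon. Among the measured compounds shown here, no step between measured compounds is available, so the size of this change cannot be read from the data. The step of a 1.3-fold lower number from compound 2 to compound 3 (0.11 log units; within the scatter) is expected to lie within the scatter, in no clear direction. Compound 3 is therefore estimated at 3000 nM, with a range from 800 nM to 12000 nM.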

Compound 3, half-maximal effective concentration: "not active" (no number reported)
For compound 3 the study gives words and no number, and the estimate cannot be compared.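

Among the compounds shown here, compound 3 is reported as "not active" (no number reported) while compound 2 carries a number, so no step between them can be read. The compounds shown leave open what size of change acetyl in place of fluoro brings. No measured evidence bears on this result.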